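From carboxy to ethoxycarbonyl on compound 2

The compounds below may be only part of what the source reports. "The series", "measured", "known", "first", "only" and "open" are said of these compounds alone.

In a functional assay on the whole organism (strain Sprague-Dawley) for inhibition, with Rattus norvegicus as the target, with a stated time of 10 min (a higher number here means that more compound is needed for the effect, a lower number that less compound is needed), compound 1 `O=C(O)c1cnc(-c2ccccc2)[nH]c1=O` gives 50 mg/kg. Compound 2 `O=C(O)c1cnc(-c2ccccc2Cl)[nH]c1=O`, with chloro in place of hydrogen on an aromatic carbon, gives 5 mg/kg. This is a 10-fold lower number from compound 1 to compound 2 (1.00 log units; beyond the scatter). Compound 3 `O=C(O)c1cnc(-c2ccccc2[N+](=O)[O-])[nH]c1=O`, with nitro at that spot, gives > 50 mg/kg, which is a limit of the assay and not a number. The remaining comparison shows an at least 10-fold higher number from compound 2 to compound 3 (1.00 log units; beyond the scatter). Compound 2 therefore has the lowest number of the three, so less of it is needed for the effect.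

Compound 4 `CCOC(=O)c1cnc(-c2ccccc2Cl)[nH]c1=O` keeps the chloro but alters another part of the molecule: ethyl in place of hydrogen on an oxygen next to a carbonyl group. Ethyl replaces hydrogen on an oxygen next to a carbonyl group, so carboxy becomes ethoxycarbonyl. Among the measured compounds shown here, none of the measured steps touches this group, since all of them change a group on an aromatic carbon. They bear on it only indirectly, by showing that one small change can shift this assay as far as a 10-fold lower number from compound 1 to compound 2 (1.00 log units; beyond the scatter). With compound 2 already low at 5 mg/kg, a move upward seems more likely than a further drop, though this is a weakly supported expectation. The expected change is a 4.0-fold higher number from compound 2 to compound 4 (0.60 log units; beyond the scatter). For compound 4 the estimated value is 20 mg/kg, with an expected range from 4 mg/kg to 100 mg/kg.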

Compound 4, dose for 50% inhibition: 5 mg/kg
Beside the measured number, compound 4's estimate is 4.0-fold (0.60 log units) above it; the measured number falls inside the stated range.
By their numbers in this assay, from the lowest: compounds 2 and 4 (each within the scatter of the next); then compound 1.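

In this assay, ethyl in place of hydrogen on the oxygen next to the carbonyl group gives no change at the digits printed from compound 2 to compound 4 (within the scatter). Among the compounds shown here, this is the first measured change away from the aromatic carbon, and it shows that carboxy can give way to ethoxycarbonyl with the number staying within the scatter, so a free carboxy hydrogen is not needed to reach the low number of compound 2 in this whole-organism test. Nothing among the data shown gives a reason for this result.

From the compounds shown here alone, the result rests on a single pair, both members of which carry the chloro, so it remains open whether ethyl would act the same way on the core of compound 1, which has hydrogen at that spot. It is also open how this position would respond to a longer chain on the same oxygen, or to an amide in place of the carboxy group, since ethoxycarbonyl is the only replacement shown.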